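The source may report more compounds than this note shows. Statements on the series, on what has been measured and on what is new or still open speak of the compounds shown alone.

In a functional assay on HL-60 cells (Homo sapiens) for inhibition, read by MTT assay, with a stated time of 72 h; on this read-out lower numbers stand for stronger inhibition and higher numbers for weaker inhibition:
- Compound 1 `COc1ccc(-c2nc(C)oc2C(=O)N2CCN(c3cccc(Cl)c3)CC2)cc1OC`: "not active" (no number reported)
- Compound 2 `CCc1nc(-c2cccc(F)c2)c(C(=O)N2CCN(c3cccc(Cl)c3)CC2)o1`: 317 nM
- Compound 3 `CCc1nc(-c2ccc(OC)cc2)c(C(=O)N2CCN(c3cccc(Cl)c3)CC2)o1`: > 1000 nM

Compound 3 gives > 1000 nM, which is a limit and not a number. Compound 4 `CCc1nc(-c2ccc(OC)c(OC)c2)c(C(=O)N2CCN(c3cccc(Cl)c3)CC2)o1` differs from it by methoxy in place of hydrogen on an aromatic carbon: methoxy in place of hydrogen, turning 4-methoxyphenyl to 3,4-dimethoxyphenyl. Among the measured compounds shown here, the one measured step on this aromatic group is an at least 3.1-fold higher number from compound 2 to compound 3 (0.49 log units; beyond the scatter), which lies beyond the scatter. Compound 1 also carries 3,4-dimethoxyphenyl and is reported as "not active" (no number reported). A gain in this assay is therefore not expected, and a step to a similar or somewhat higher number seems likelier. The expected step is a step that the limit leaves unreadable from compound 3 to compound 4. For compound 4 the estimated value is 2000 nM, with an expected range from 700 nM to 10000 nM.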

Compound 4, half-maximal inhibitory concentration: "not active" (no number reported)
Compound 4 has no reported number here, and the estimate cannot be compared.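

With compound 3 known only as a limit and compound 4 reported without a number in this assay, no step can be read between them. Going by these compounds, whether 3,4-dimethoxyphenyl in place of 4-methoxyphenyl changes inhibition at all remains open.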